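From Phenyl to 4-Chlorophenyl: Expecting Little Change

The source may hold more compounds than are shown below. What is called first, only, known or untested is meant among the compounds shown, and "the series" means these compounds.

Of the compounds shown here, three built on one shared core have been tested in a functional assay on PC-12 cells (Rattus norvegicus) for cytotoxicity, read by MTT assay, with stated times of 3 h and 2 h, tested at 5 uM; on this read-out higher numbers stand for a stronger effect at the one concentration tested and lower numbers for a weaker effect. Compound 1 `Cc1cc(=O)oc2cc(OCCCn3cc(CNC(=O)CCCCC4CCSS4)nn3)ccc12` gives 64.6% in this assay. Compound 2 `CC(=O)c1cc2ccc(OCCCn3cc(CNC(=O)CCCCC4CCSS4)nn3)cc2oc1=O` gives 37.5%. Compound 3 `O=C(CCCCC1CCSS1)NCc1cn(CCCCOc2ccc3cc(-c4ccccc4)c(=O)oc3c2)nn1` gives 32.8%, the lowest of the three numbers; the gap between compound 3 and compound 2 lies within the usual scatter, so the two cannot be told apart, whereas compound 1 stands beyond the scatter above compound 3.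

Compound 4 `O=C(CCCCC1CCSS1)NCc1cn(CCCCOc2ccc3cc(-c4ccc(Cl)cc4)c(=O)oc3c2)nn1` differs from compound 3 in one place: chloro in place of hydrogen on an aromatic carbon. Read one bond further out, the change is phenyl to 4-chlorophenyl, with the chloro placed para to a large group.

For the measured compounds named here, no pair of measured compounds differs by such a change, so the three numbers give no direct guide to its effect, and nothing among them suggests that this single substitution should move the read-out far. The step is therefore expected to be small, a number 2.2 percentage points higher from compound 3 to compound 4 (within the scatter), in no firm direction and not beyond the scatter. Compound 4 is expected to give about 35% in this assay, somewhere between 20% and 52%.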

Compound 4, a percentage reported as activity, at one concentration (the size of the read-out at that concentration, not a potency): 52%
Estimate against measurement, compound 4: 17 percentage points below, within the range that was stated.
By their numbers in this assay, from the lowest: compounds 3 and 2 (each within the scatter of the next); then compound 4; then compound 1.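

For the compounds shown here, changing one hydrogen to chloro on the phenyl ring of compound 3 is the first single-place change seen, and in this assay it gives a number 19.2 percentage points higher from compound 3 to compound 4 (beyond the scatter) as the measured step. This shows that the read-out responds to a one-atom change on this aromatic carbon, para to a large group, so the phenyl ring is not a silent part of the molecule in this assay, even though the step rests on a single pair of compounds at a single concentration. Nothing measured here gives a reason for the step, so the data show the size of the change but not its cause.

As far as these compounds go, it remains open whether this step belongs to chloro in particular or would also appear with another group in the same place, such as fluoro, methoxy, an amine or a carboxylic acid. Also open, from the compounds shown here alone, is whether chloro would produce a similar step on a different carbon of the phenyl ring, or on the same ring with a longer chain linking the shared core to the triazole-bearing part of the molecule.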